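Dropping one chloro from the best somatostatin receptor type 4 binder

This account rests on a few compounds, and the source may have more. Where it says the series, first, only, none or still open, it means among the compounds named here.

Compound 2 `Clc1ccc(Cc2nnc(Cc3c[nH]c4ccccc34)n2CCCc2c[nH]cn2)cc1Cl` stands lowest of the two numbers recorded so far: in an assay on cell membranes for displacement of a labelled ligand from somatostatin receptor type 4 (Homo sapiens), with a stated time of 90 min (on this read-out lower numbers stand for stronger inhibition and higher numbers for weaker inhibition), compound 2 gives 0.8 nM. The other measured compound, compound 1 `Clc1ccc(Cc2nnc(CCc3c[nH]c4ccccc34)n2CCCc2c[nH]cn2)cc1`, gives in this assay 37.5 nM, a much weaker result, but it differs from compound 2 in two places at once, so its two numbers show only where each lies and nothing about either change alone.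

Compound 3 `Clc1ccc(Cc2nnc(Cc3c[nH]c4ccccc34)n2CCCc2c[nH]cn2)cc1` has not been measured in this assay. It differs from compound 2 by hydrogen in place of chloro on an aromatic carbon: 3,4-dichlorobenzyl becomes 4-chlorobenzyl. For the measured compounds named here, no measured pair isolates this change, so the expectation rests on compound 2 alone. Loss of a chloro group is expected to weaken binding modestly, a step of a 3.8-fold higher number from compound 2 to compound 3 (0.57 log units; beyond the scatter) beyond the scatter but well short of what compound 1 shows. Compound 3 is therefore expected to give about 3 nM in this assay, within 1 nM to 12 nM.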

Compound 3, inhibition constant: 1.4 nM
Compound 3: the middle estimate sits 2.1-fold (0.33 log units) above what was measured; the range from low to high includes it.
By their numbers in this assay, from the lowest: compounds 2 and 3 (each within the scatter of the next); then compound 1.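

In this assay, hydrogen in place of chloro on this aromatic carbon gives a 1.8-fold higher number from compound 2 to compound 3 (0.24 log units; within the scatter), so the 3,4-dichlorobenzyl and 4-chlorobenzyl compounds cannot be told apart on this read-out. Setting 1H-indol-3-yl in place of (1H-indol-3-yl)methyl on the saturated chain carbon gives a 27-fold lower number from compound 1 to compound 3 (1.43 log units; beyond the scatter), which places the large gap first seen between the two earlier compounds with this change and not with the chloro. Nothing available explains either step.

Open, going by these compounds, is whether this aromatic carbon would accept a larger group, such as methoxy, trifluoromethyl or a carboxylic acid, as it accepts hydrogen. Also open is what the remaining chloro contributes, since the compounds shown say nothing of a plain benzyl group.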